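The source may report more compounds than this note shows. Statements on the series, on what has been measured and on what is new or still open speak of the compounds shown alone.

Measured so far in a functional assay on NCI-H522 cells (Homo sapiens) for inhibition, read by sulforhodamine B assay, with a stated time of 48 h; a lower number here means that less compound is tolerated, a higher number that more compound is tolerated:
Compound 1 `COc1cc(-c2nn(-c3cccc(NC(=O)Nc4ccc(Cl)c(Cl)c4)c3)cc2-c2ccncc2)ccc1Cl` gives only a limit, > 50000 nM.
Compound 2 `O=C(Nc1cccc(-n2cc(-c3ccncc3)c(-c3ccc(Cl)c(O)c3)n2)c1)Nc1ccc(Cl)c(Cl)c1` gives only a limit, > 32500 nM.
Compound 3 `O=C(Nc1cccc(-n2cc(-c3ccncc3)c(-c3ccc(Cl)c(O)c3)n2)c1)Nc1cc(C(F)(F)F)cc(C(F)(F)F)c1` gives 12800 nM.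

Compound 2 thus stands at a limit of > 32500 nM in this assay, at which 1 of the 3 values shown sits, and not at a number. Going by the values given here, the only measured step, a step that the two limits leave unreadable from compound 1 to compound 2, is unreadable, both ends sitting at limits the limit of > 50000 nM in this assay, at which 1 of the 3 values shown sits, and (the limit of > 32500 nM in this assay, at which 1 of the 3 values shown sits), so no measured step bears on the change now considered. Compound 4 `O=C(Nc1cccc(-n2cc(-c3ccncc3)c(-c3ccc(Cl)c(O)c3)n2)c1)Nc1ccc(Cl)c(C(F)(F)F)c1` differs from compound 2 by trifluoromethyl in place of chloro on an aromatic carbon. Among the compounds with values here, compound 3 is the only compound with a number, and it carries a different substitution on the same ring; it gives the only anchor. The value of compound 4 is therefore expected near the limit of compound 2, with a step of an at least 1.0-fold lower number from compound 2 to compound 4 (0.03 log units; that floor lies within the scatter) that is itself not expected beyond the scatter. Compound 4 is estimated at 30000 nM, between 9000 nM and 60000 nM.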

Compound 4, concentration lethal to 50% of the cells: 24500 nM
Compound 4: the middle estimate sits 1.2-fold (0.09 log units) above what was measured, and the stated range covers the measured number.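

In this assay, trifluoromethyl in place of chloro, on the aromatic carbon ortho to a chloro group and meta to a large group, gives an at least 1.3-fold lower number from compound 2 to compound 4 (0.12 log units; that floor lies within the scatter). This is the only readable step among the compounds shown, and the only one at this position. Compound 2, at > 32500 nM, stands at a limit and not at a number, so only a floor is known for this step.

From the compounds shown here alone, whether the true step lies beyond the scatter stays open. So does what a nitrile or an amine would give at this position.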